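Series notes: from compound 2 toward compound 4

The compounds below may be only part of what the source reports. "The series", "measured", "known", "first", "only" and "open" are said of these compounds alone.

Compound 1 `Cc1nc2ccc(Br)cc2c(=O)n1NCc1nnc(N2C(=O)CSC2c2ccc(O)cc2)s1` gives 60% in a functional assay on the whole organism (strain albino) with Rattus norvegicus as the target, in the maximal electroshock model, with a stated time of 1 h, at a dose of 30 mg/kg by the intraperitoneal route; a higher number here means more inhibition at the dose given (going by the name of the read-out), a lower number less inhibition. Compound 2 `COc1cc(C2SCC(=O)N2c2nnc(CNn3c(C)nc4ccc(Br)cc4c3=O)s2)ccc1O` gives 60% in this assay, and compound 3 `COc1cc(C2SCC(=O)N2c2nnc(CNn3c(C)nc4ccccc4c3=O)s2)ccc1O` gives 60%. On these numbers compound 2 stands level with compounds 1 and 3: the step of no change at the digits printed from compound 1 to compound 2 (within the scatter) and the step of no change at the digits printed from compound 2 to compound 3 (within the scatter) both lie within the scatter. Compound 4 `COc1ccc(C2SCC(=O)N2c2nnc(CNn3c(C)nc4ccc(Br)cc4c3=O)s2)cc1` differs from compound 2 by 4-methoxyphenyl in place of 4-hydroxy-3-methoxyphenyl on a saturated ring carbon. Among the measured compounds shown here, no measured step removes a hydroxy group; the two steps that bear on it, each a change on an aromatic carbon, left the read-out unmoved, so the expected step of no change at the digits printed from compound 2 to compound 4 (within the scatter) is none beyond the scatter. Compound 4 is estimated at 60%, with an expected range from 45% to 75%.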

Compound 4, a percentage reported as inhibition, in the whole organism at one dose (the size of the read-out at that dose, not a potency): 60%
Estimate against measurement, compound 4: no gap at the digits printed, and the stated range covers the measured number.
By their numbers in this assay, from the lowest: compounds 1, 2, 3 and 4 (each within the scatter of the next).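

In this assay the step to 4-methoxyphenyl on the saturated ring carbon, which removes the hydrogen-bond donor and one oxygen, reads no change at the digits printed from compound 2 to compound 4 (within the scatter) and so adds a change at this position itself to the earlier aromatic-carbon changes. Methyl in place of hydrogen on the aromatic oxygen likewise reads no change at the digits printed from compound 1 to compound 4 (within the scatter) so neither version of the change separates these compounds at this dose. Nothing available explains this flat result. Open, as far as these compounds go, is whether an amine or a carboxylic acid on this phenyl ring, or a longer chain on its oxygen, would move the read-out. A single dose also leaves any difference in potency among these compounds unresolved.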